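Aryl swap on the chain carbon of compound 1

The source may hold more compounds than are shown below. What is called first, only, known or untested is meant among the compounds shown, and "the series" means these compounds.

Compound 1 `COc1ccccc1/C=C(/Sc1ccc(C)cc1)C(=O)c1ccc(Cl)cc1` gives the highest of the three numbers in a functional assay on DU-145 cells (Homo sapiens) for inhibition, read by trypan blue exclusion, with a stated time of 96 h (on this read-out higher numbers stand for weaker inhibition of growth and lower numbers for stronger inhibition of growth), at 25000 nM. Compound 2 `COc1ccccc1/C=C(/SCc1ccc(C)cc1)C(=O)c1ccc(Cl)cc1` gives 10000 nM in this assay, and compound 3 `COc1ccccc1/C=C(/Sc1ccc(Br)cc1)C(=O)c1ccc(Cl)cc1` gives 10000 nM. The steps of a 2.5-fold lower number from compound 1 to compound 2 (0.40 log units; beyond the scatter) and a 2.5-fold lower number from compound 1 to compound 3 (0.40 log units; beyond the scatter) both alter the group on the sulfur, while no change at the digits printed from compound 2 to compound 3 (within the scatter). Compound 4 `Cc1ccc(S/C(=C/c2ccc(Cl)cc2Cl)C(=O)c2ccc(Cl)cc2)cc1` is not yet measured; it differs from compound 1 by 2,4-dichlorophenyl in place of 2-methoxyphenyl on a double-bonded chain carbon bound to a double-bonded chain carbon. Going by the values given here, no measured step touches the ring on the double-bonded chain carbon, so none bears on this change, and the series gives no basis for a direction beyond the scatter. The estimated step is therefore a 1.7-fold lower number from compound 1 to compound 4 (0.22 log units; within the scatter), kept close to no change. In this assay compound 4 is estimated at 15000 nM, within 5000 nM to 50000 nM.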

Compound 4, concentration for 50% growth inhibition: 10000 nM
For compound 4 the middle estimate is 1.5-fold (0.18 log units) above the measured one, within the range that was stated.
By their numbers in this assay, from the lowest: compounds 2, 3 and 4 (each within the scatter of the next); then compound 1.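

The ring on the double-bonded chain carbon bound to a double-bonded chain carbon affects the read-out: 2,4-dichlorophenyl in place of 2-methoxyphenyl gives a 2.5-fold lower number from compound 1 to compound 4 (0.40 log units; beyond the scatter) in this assay. This step matches in size those seen at the sulfur, while the group on the sulfur stays unchanged. No evidence on hand accounts for the step.

Open, on these data alone, is whether a pyridine ring or an aminophenyl at this position would move the number further. Also open, as far as these compounds go, is whether 2,4-dichlorophenyl combined with 4-bromophenyl on the sulfur would add to either step.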